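Cyano on the pendant phenyl of a spiro-lactone sigma ligand

This account rests on a few compounds, and the source may have more. Where it says the series, first, only, none or still open, it means among the compounds named here.

Compound 1 `O=C1OC2(CCN(Cc3ccccc3)CC2)c2c1csc2-c1ccccc1`: 483 nM
Compound 2 `O=C1OC2(CCN(Cc3ccccc3)CC2)c2c(-c3ccccc3)sc(-c3ccccc3)c21`: 87 nM

For the measured compounds named here, in an assay on membranes from brain for displacement of a labelled ligand from Sigma non-opioid intracellular receptor 1 (Cavia porcellus), read by scintillation counting, with a stated time of 120 min (a lower number here means a stronger inhibitor, a higher number a weaker inhibitor), compound 1 gives 483 nM, the higher of the two numbers measured so far, and compound 2 gives 87 nM. Going by the values given here, the one step available, a 5.6-fold lower number from compound 1 to compound 2 (0.74 log units; beyond the scatter), involves phenyl in place of hydrogen on an aromatic carbon of the shared core.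

Compound 3 `N#Cc1ccc(-c2scc3c2C2(CCN(Cc4ccccc4)CC2)OC3=O)cc1` differs from compound 1 by cyano in place of hydrogen on an aromatic carbon, that is, phenyl to 4-cyanophenyl. Among the compounds with values here, no measured step touches this phenyl ring, and no measured compound carries a cyano group, so the step from compound 1 to compound 2 does not bear directly on the change. With nothing to point either way, compound 3 is expected to land near compound 1, with a step of a 1.2-fold lower number from compound 1 to compound 3 (0.08 log units; within the scatter) that stays within the usual scatter. The estimate for compound 3 in this assay is 400 nM, in a range from 130 nM to 1500 nM.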

Compound 3, inhibition constant: 190 nM
The estimate for compound 3 lay 2.1-fold (0.32 log units) above the measured number; measured number inside the range.
By their numbers in this assay, from the lowest: compound 2; then compound 3; then compound 1.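

In this assay, for the compounds shown here, the pendant phenyl, which no earlier step touched, proves open to substitution: cyano in place of hydrogen, para to a large group, gives a 2.5-fold lower number from compound 1 to compound 3 (0.41 log units; beyond the scatter) and brings a gain in binding strength rather than a loss. The step is modest, but it shows that this position accepts a group of 2 heavy atoms with a triple bond. Nothing measured here explains why the number falls with this change.

The compounds shown leave open whether this gain is particular to cyano or would also appear with a fluorine atom, a methoxy group, an amine or a carboxylic acid at the same place. From the compounds shown here alone, it is also open whether cyano at this position would give a similar step on compound 2, which carries a second phenyl.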